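Pyrazoline sulfonamides: aryl replacement at the saturated ring carbon

A few compounds are considered here, and "the series" means these few. Any claim that something is new, unique, unknown or untested is made for them only; others in the source may bear on it.

Of the compounds shown here, two have a number so far in a functional assay on COLO 205 cells (Homo sapiens) for antiproliferative activity, with a stated time of 48 h; on this read-out lower numbers stand for stronger inhibition of growth and higher numbers for weaker inhibition of growth. Compound 1 `Cc1cc(O)c(C2=NN(c3ccc(S(N)(=O)=O)cc3)C(c3ccccc3Cl)C2)cc1Cl` gives 1810 nM. Within the data shown here, compound 2 `Cc1cc(O)c(C2=NN(c3ccc(S(N)(=O)=O)cc3)C(/C=C/c3ccccc3)C2)cc1Cl` gives 10400 nM, the highest of the two numbers, with compound 1 nearest to it; the only measured step, a 5.7-fold higher number from compound 1 to compound 2 (0.76 log units; beyond the scatter), runs from compound 1 to compound 2 and lies beyond the scatter.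

Compound 3 `COc1ccc(C2CC(c3cc(Cl)c(C)cc3O)=NN2c2ccc(S(N)(=O)=O)cc2)cc1OC` has not yet been measured in this assay. Its structural difference from compound 2 is 3,4-dimethoxyphenyl in place of 2-phenylethenyl on a saturated ring carbon. Among the measured compounds shown here, this change bears a relation to the one measured step: it removes the 2-phenylethenyl group that entered in a 5.7-fold higher number from compound 1 to compound 2 (0.76 log units; beyond the scatter) and restores a group of the same kind as in compound 1, a six-membered aromatic ring of carbon only, set directly on the saturated ring carbon. The substitution on that ring differs from compound 1, so the size of the step is uncertain, but a step back toward the number of compound 1 is expected, that is, a modest lowering beyond the scatter.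

The estimate for compound 3 is therefore 2500 nM, within a range of 800 nM to 8000 nM, which corresponds to an expected step of a 4.2-fold lower number from compound 2 to compound 3 (0.62 log units; beyond the scatter).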

Compound 3, concentration for 50% growth inhibition: 1930 nM
Compound 3: middle estimate off by 1.3-fold (0.11 log units), on the high side; low and high end bracket the measured number.
By their numbers in this assay, from the lowest: compounds 1 and 3 (each within the scatter of the next); then compound 2.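

In this assay, the step of a 5.4-fold lower number from compound 2 to compound 3 (0.73 log units; beyond the scatter) shows that replacing 2-phenylethenyl with 3,4-dimethoxyphenyl on the saturated ring carbon also gives a lower number, so this change is not tied to the 2-chlorophenyl group alone. The step of a 1.1-fold higher number from compound 1 to compound 3 (0.03 log units; within the scatter) shows that 2-chlorophenyl and 3,4-dimethoxyphenyl cannot be told apart at this position, although the two rings carry different substituents and only 3,4-dimethoxyphenyl brings hydrogen-bond acceptors. Among these three compounds, only compound 2, the one without an aromatic ring set directly on the saturated ring carbon, stands apart, and no supporting measurement bears on the reason for this.

Going by these compounds, it remains open whether the higher number of compound 2 goes with the double bond outside aromatic rings, which a 2-phenylethyl group at the same carbon would test, or with the spacing of the phenyl ring from the saturated ring carbon. Also open, on these data alone, is how far this position tolerates other kinds of group, such as unsubstituted phenyl, pyridyl, cyclohexyl or a phenyl ring bearing a carboxylic acid or an amine.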